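The source may hold more compounds than are shown below. What is called first, only, known or untested is meant among the compounds shown, and "the series" means these compounds.

Measured in an assay on HEK293 cells for antagonist activity at transient receptor potential cation channel subfamily V member 3 (Homo sapiens), read by FLIPR and calcium flux; a lower number here means a stronger inhibitor, a higher number a weaker inhibitor:
Compound 1 `C[C@]1(O)C[C@](c2cccc(C(F)(F)F)c2)([C@H](O)c2ccccn2)C1` gives 1550 nM.
Compound 2 `O[C@H](c1ccccn1)[C@]1(c2cccc(C(F)(F)F)c2)C[C@H](O)C1` gives 90 nM.
Compound 3 `C[C@]1(O)C[C@](c2ccnc(C(F)(F)F)c2)([C@H](O)c2ccccn2)C1` gives 500 nM.

Compound 1 and compound 2 differ in one place only: hydrogen in place of methyl on a saturated ring carbon. The measured step is a 17-fold lower number from compound 1 to compound 2 (1.24 log units; beyond the scatter), so this single change moves the number well beyond the scatter within this pair.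

Compound 3 carries a different core from compound 1; the difference between the two cores is not broken down here. In this assay compound 3 sits second highest of the three numbers: its value is lower than that of compound 1 and higher than that of compound 2, both gaps beyond the scatter.

Compound 4 `O[C@H](c1ccccn1)[C@]1(c2ccnc(C(F)(F)F)c2)C[C@H](O)C1` has not yet been measured. It stands to compound 3 as compound 2 stands to compound 1: hydrogen in place of methyl on a saturated ring carbon. Within the data shown here, the place of the change is described in the same words for both pairs, so it is the same change on a second core, with only one measured precedent.

The expectation for compound 4 rests on that precedent: a step of about the size of a 17-fold lower number from compound 1 to compound 2 (1.24 log units; beyond the scatter) is expected again, giving a 14-fold lower number from compound 3 to compound 4 (1.15 log units; beyond the scatter). Since a single pair carries the whole weight, the range is kept wide. The estimated value for compound 4 in this assay is 35 nM, expected to fall between 10 nM and 120 nM.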

Compound 4, antagonist equilibrium constant: 60 nM
Beside the measured number, compound 4's estimate is 1.7-fold (0.23 log units) below it; the measured number falls inside the stated range.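

In this assay, hydrogen in place of methyl on a saturated ring carbon of the four-membered ring gives an 8.3-fold lower number from compound 3 to compound 4 (0.92 log units; beyond the scatter), so on the second core the change again lowers the number, and by more than the scatter. Set beside the earlier step, the two sizes cannot be told apart: the same change on two cores in this assay, a 17-fold lower number (1.24 log units; beyond the scatter) from compound 1 to compound 2 and an 8.3-fold lower number (0.92 log units; beyond the scatter) from compound 3 to compound 4, 2.1-fold (0.32 log units) apart, within the scatter of two such steps. Among these compounds, this supports carrying the change between these two cores, in both direction and approximate size, but it rests on only two pairs and does not show that the step would hold on any other core, nor does it explain why the change has this effect.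

Only methyl and hydrogen occupy this ring carbon in the compounds shown, so it remains open how an ethyl group, a fluorine or an amine at the same place would compare in this series. Also open, from the compounds shown here alone, is whether the step would survive replacing the hydroxy(pyridin-2-yl)methyl group, for instance with a chain ending in a carboxylic acid, since that group is the same in all four compounds.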